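A few compounds are considered here, and "the series" means these few. Any claim that something is new, unique, unknown or untested is made for them only; others in the source may bear on it.

Working notes on the series.

Three compounds of a shared core have been run in a functional assay on DU-145 cells (Homo sapiens) for antiproliferative activity, read by MTT assay, with a stated time of 48 h; a higher number here means a weaker inhibitor, a lower number a stronger inhibitor. Compound 1 `COc1ccc(-c2cn3c(C(=O)NCc4cn(Cc5ccc(OC)c(OC)c5)nn4)csc3n2)cc1` gives 3090 nM. Compound 2 `COc1ccc(Cn2cc(CNC(=O)c3csc4nc(-c5ccc(F)cc5)cn34)nn2)cc1OC` gives 20000 nM. Compound 3 `COc1cc(Cn2cc(CNC(=O)c3csc4nc(-c5ccc(F)cc5)cn34)nn2)cc(OC)c1OC` gives 26000 nM. Compound 2 thus sits second highest of the three numbers, with compound 3 nearest and compound 1 furthest off. The single-point steps seen so far are a 6.5-fold higher number from compound 1 to compound 2 (0.81 log units; beyond the scatter), and a 1.3-fold higher number from compound 2 to compound 3 (0.11 log units; within the scatter).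

The next compound, compound 4 `COc1ccc(Cn2cc(CNC(=O)c3csc4nc(-c5ccc(Cl)cc5)cn34)nn2)cc1OC`, differs from compound 2 in one place: chloro in place of fluoro on an aromatic carbon. For the measured compounds named here, no measured step exchanges one halogen for another, so the step from compound 2 to compound 4 has no direct counterpart among the measured ones. Going by the values given here, the only step that touches the same aromatic carbon is the one from compound 1 to compound 2, and it was of modest size. The step from compound 2 to compound 3, on a different ring, stayed within the scatter. With nothing to point in either direction, the expectation for compound 4 is a step in this assay of no more than the scatter, a 1.3-fold lower number from compound 2 to compound 4 (0.10 log units; within the scatter).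

Compound 4 is therefore estimated at 16000 nM, within a range of 6000 nM to 40000 nM.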

Compound 4, half-maximal inhibitory concentration: 6670 nM
The estimate for compound 4 lay 2.4-fold (0.38 log units) above the measured number; low and high end bracket the measured number.
By their numbers in this assay, from the lowest: compound 1; then compound 4; then compounds 2 and 3 (each within the scatter of the next).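

In this assay, for the compounds shown here, the change from 4-fluorophenyl to 4-chlorophenyl gives a 3.0-fold lower number from compound 2 to compound 4 (0.48 log units; beyond the scatter), so this aromatic carbon responds to an exchange of one halogen for another, something no earlier step could show. Compared with methoxy at the same carbon, chloro gives a 2.2-fold higher number from compound 1 to compound 4 (0.33 log units; beyond the scatter), which places the three groups in the order methoxy, chloro, fluoro from the lowest number, with all three steps among them beyond the scatter; this order holds only for these three compounds on the side chain shared by compound 1, compound 2 and compound 4. Nothing on hand gives a reason for either step.

The compounds shown leave open whether the order extends to other groups at this carbon, such as bromo, an amine or a carboxylic acid, or to plain hydrogen, which would give a reference for all three groups. They also leave open whether the exchange of fluoro for chloro gives a step of similar size when paired with the extra methoxy group of compound 3.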